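The compounds below may be only part of what the source reports. "The series", "measured", "known", "first", "only" and "open" are said of these compounds alone.

The measured compounds:
compound 1, `COc1ccccc1/C=C/C(=O)OC/C=C/c1cc(OC)c(OC)cc1OC`, gives 100% in a functional assay on the whole organism (strain Kunming) with Mus musculus as the target, with a stated time of 0.5 h, at a dose of 300 mg/kg by the intraperitoneal route; a lower number here means a stronger effect, a higher number a weaker effect of the compound at the dose given
compound 2, `COc1cc(OC)c(OC)cc1/C=C/COC(=O)/C=C/c1ccccc1C(F)(F)F`, gives 100% in this assay
compound 3, `COc1cc(OC)c(OC)cc1/C=C/COC(=O)/C=C/c1cc(OC)c(OC)c(OC)c1`, gives 100% in this assay

All three share one core and differ only in the aryl group on the cinnamate side. Within the data shown here, compound 2 stands level with compounds 1 and 3 at the digits printed, and the single one-place step, no change at the digits printed from compound 1 to compound 2 (within the scatter), lies within the scatter, so no trend is visible in these numbers. Compound 4, `COc1cc(OC)c(OC)cc1/C=C/COC(=O)/C=C/c1ccc(F)cc1`, is the next member, differing from compound 2 in this way: 4-fluorophenyl in place of 2-(trifluoromethyl)phenyl on a double-bonded chain carbon bound to a double-bonded chain carbon. Among the measured compounds shown here, the one measured step that bears on this change is no change at the digits printed from compound 1 to compound 2 (within the scatter), which also replaced a group on the phenyl ring of the cinnamate and showed no change beyond the scatter; compounds 1 and 3, with still other aryl groups, give the same read-out. The step of no change at the digits printed from compound 2 to compound 4 (within the scatter) is therefore expected to show no change beyond the scatter. Compound 4 is estimated to give 100% in this assay, within a range from 83% to 100%.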

Compound 4, a percentage reported as activity, at one dose (the size of the read-out at that dose, not a potency): 100%
Compound 4: the middle estimate sits on the measured number at the digits printed, and the stated range covers the measured number.
By their numbers in this assay, from the lowest: compounds 1, 2, 3 and 4 (each within the scatter of the next).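

The new result extends the flat picture to a different kind of aryl group on this double-bonded chain carbon: no change at the digits printed from compound 2 to compound 4 (within the scatter) in this assay, and likewise no change at the digits printed from compound 1 to compound 4 (within the scatter). The 4-fluorophenyl group has fewer heavy atoms than the 2-(trifluoromethyl)phenyl group it replaces, yet neither this change nor the change from 2-methoxyphenyl separates the compounds at this dose. No accompanying measurement offers an explanation for this sameness.

The compounds shown leave open whether an aryl group carrying an amine or a carboxylic acid, or a longer alkyl chain in place of the aryl group, would shift this read-out. They also leave open whether any change to the shared core would do so.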